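This account rests on a few compounds, and the source may have more. Where it says the series, first, only, none or still open, it means among the compounds named here.

Compound 1 `COc1ccc(Cn2c(CCc3c[nH]c4ccccc34)nnc2[C@H](NC(=O)c2ccccn2)c2c[nH]c3ccccc23)cc1` gives 1.9 nM in an in vitro assay on LLC-PK1 cells for displacement of a labelled ligand from growth hormone secretagogue receptor type 1 (Homo sapiens); a higher number here means a weaker inhibitor, a lower number a stronger inhibitor. Compound 2 `O=C(N[C@H](c1c[nH]c2ccccc12)c1nnc(CCc2c[nH]c3ccccc23)n1-c1ccccc1)c1ccccn1` gives 160 nM. Their difference is phenyl in place of 4-methoxybenzyl on an aromatic nitrogen, and this change produced an 84-fold higher number from compound 1 to compound 2 (1.93 log units; beyond the scatter). Compound 3 `COc1ccc(Cn2c(CCc3ccccc3)nnc2[C@H](NC(=O)Cc2ccccn2)c2c[nH]c3ccccc23)cc1` gives 3 nM; how its core differs from that of compound 1 is not broken down here. Compound 4 `O=C(Cc1ccccn1)N[C@H](c1c[nH]c2ccccc12)c1nnc(CCc2ccccc2)n1-c1ccccc1` has not been measured. It differs from compound 3 by phenyl in place of 4-methoxybenzyl on an aromatic nitrogen, the same kind of change, though here the place is next to the ring atom that bears a phenethyl group rather than a 2-(1H-indol-3-yl)ethyl group. Because an 84-fold higher number from compound 1 to compound 2 (1.93 log units; beyond the scatter) was large, a similar weakening is expected, so compound 4 is estimated at 200 nM, from 60 nM to 700 nM, an expected step of a 67-fold higher number from compound 3 to compound 4 (1.82 log units; beyond the scatter).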

Compound 4, half-maximal inhibitory concentration: 700 nM
For compound 4 the middle estimate is 3.5-fold (0.54 log units) below the measured one, within the range that was stated.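

On both cores, putting phenyl in place of 4-methoxybenzyl on the aromatic nitrogen weakens binding in this assay by a large margin, with a 230-fold higher number from compound 3 to compound 4 (2.37 log units; beyond the scatter) on the second core. The direction of the change therefore carries from one core to the other, but its size does not carry over exactly: the same change on two cores in this assay, an 84-fold higher number (1.93 log units; beyond the scatter) from compound 1 to compound 2 and a 230-fold higher number (2.37 log units; beyond the scatter) from compound 3 to compound 4, 2.8-fold (0.44 log units) apart, beyond the scatter of two such steps
Two cores do not show which of their differences sets the size of the step, nor what the change would do on a further core.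

The compounds shown leave open whether the loss follows from removing the methoxy group or the carbon link to the ring, which plain benzyl could separate. On these data alone, how a longer chain such as phenethyl, or a benzyl bearing an amine or a carboxylic acid, would behave on that nitrogen also remains open.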